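The source may hold more compounds than are shown below. What is called first, only, known or untested is meant among the compounds shown, and "the series" means these compounds.

The measured compounds and their values:

- compound 1, `O=C(O)[C@H]1NC[C@H](O)[C@H](O)[C@@H]1O`: 4.5%
- compound 2, `O=C(O)[C@@H]1NC[C@@H](O)[C@@H](O)[C@@H]1O`: 7.2%

In an assay for inhibition of alpha-N-acetylgalactosaminidase (Gallus gallus), tested at 1000 uM (on this read-out lower numbers stand for less inhibition and higher numbers for more inhibition at the one concentration tested (going by the name of the read-out)), compound 1 gives 4.5%, the lowest of the two numbers. In this assay compound 2 gives 7.2%. Going by the values given here, the only measured step is a number 2.7 percentage points higher from compound 1 to compound 2 (within the scatter), so the two values lie within the scatter of each other and show no change that can be trusted.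

Compound 3, `O=C(O)[C@@H]1NC[C@H](O)[C@H](O)[C@H]1O`, is not yet measured in this assay. It differs from compound 1 in this way: the two compounds have the same atoms and bonds and differ only in configuration as drawn: 2 of 4 stereo elements differ; a stereocentre at a saturated ring carbon is drawn S in compound 1 and R in compound 3; a stereocentre at a saturated ring carbon is drawn R in compound 1 and S in compound 3. Among the compounds with values here, the one measured step that bears on this change is a number 2.7 percentage points higher from compound 1 to compound 2 (within the scatter), and it rests on (the fact that compounds 1 and 2 differ only in the configuration as drawn); that step was within the scatter, and it too was a change of configuration alone, with no atom leaving or entering. Within the data shown here, with the sole comparable step showing no shift beyond the scatter, and both measured numbers low, no step beyond the scatter is expected from compound 1 to compound 3 in this assay, in either direction.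

For compound 3 the expected value in this assay is 6%, with a likely range from 0% to 18%, which corresponds to an expected step of a number 1.5 percentage points higher from compound 1 to compound 3 (within the scatter).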

Compound 3, a percentage reported as inhibition, at one concentration (the size of the read-out at that concentration, not a potency): 4.4%
Compound 3: middle estimate off by 1.6 percentage points, on the high side, and the stated range covers the measured number.
By their numbers in this assay, from the lowest: compounds 3, 1 and 2 (each within the scatter of the next).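

In this assay, the step from the new compound to each earlier one can now be read: a number 0.1 percentage points lower from compound 1 to compound 3 (within the scatter), and a number 2.8 percentage points lower from compound 2 to compound 3 (within the scatter). The earlier compounds shown here offered one comparison, a change at three stereocentres, whereas there are now also a change at two stereocentres and a second, different change at three, and none of them moves the number beyond the scatter. Across these three compounds, redrawing the saturated ring carbons therefore gives no sign that one of these configurations inhibits more than another at the one concentration tested, and no atom leaves or enters in the comparison with compound 1: the fact that compounds 1 and 3 differ only in the configuration as drawn

Every compound shown has the same atoms and bonds, so it stays open whether an amide or ester in place of the carboxylic acid, or a longer chain on the shared core, would bring a step beyond the scatter. Going by these compounds, each step here also changes two or three stereocentres at once, so the effect of changing a single stereocentre alone remains unknown.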